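The compounds below may be only part of what the source reports. "The series", "measured", "known", "first", "only" and "open" are said of these compounds alone.

Measured so far:
compound 1 `COc1ccc(/C=C/C2(C)C=CC(=O)O2)c(OC)c1` gives 63500 nM
compound 2 `COc1cc(OC)c(OC)cc1/C=C/C1(C)C=CC(=O)O1` gives 184000 nM

In a functional assay on PC-3 cells (Homo sapiens) for inhibition, read by sulforhodamine B assay, with a stated time of 48 h (on this read-out higher numbers stand for weaker inhibition of growth and lower numbers for stronger inhibition of growth), compound 1 stands lowest of the two numbers, and compound 2 is its nearest neighbour. Unmeasured compound 3 `COc1cc(OC)c(/C=C/C2(C)C=CC(=O)O2)c(OC)c1` differs from compound 1 by one change: methoxy in place of hydrogen on an aromatic carbon. This is a methoxy in place of hydrogen on an aromatic carbon, ortho to a group of 9 heavy atoms and meta to two methoxy groups.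

Going by the values given here, one measured step bears on it, also a methoxy in place of hydrogen on an aromatic carbon: a 2.9-fold higher number from compound 1 to compound 2 (0.46 log units; beyond the scatter). That step is modest but beyond the scatter. Among the compounds with values here, it is the only guide, and the data do not show whether its size carries over to this carbon. In this assay a modest step towards a higher number is therefore expected, somewhat smaller than the measured one, and a step within the scatter cannot be excluded. The expected step is a 2.0-fold higher number from compound 1 to compound 3 (0.29 log units; within the scatter). The estimated value for compound 3 is 125000 nM, with an expected range from 50000 nM to 300000 nM.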

Compound 3, concentration for total growth inhibition: 239000 nM
The estimate for compound 3 lay 1.9-fold (0.28 log units) below the measured number; measured number inside the range.
By their numbers in this assay, from the lowest: compound 1; then compounds 2 and 3 (each within the scatter of the next).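

In this assay, methoxy in place of hydrogen on the aromatic carbon ortho to a group of 9 heavy atoms and meta to two methoxy groups gives a 3.8-fold higher number from compound 1 to compound 3 (0.58 log units; beyond the scatter), so on this carbon the change weakens inhibition of growth by a margin beyond the scatter. Together with a 2.9-fold higher number from compound 1 to compound 2 (0.46 log units; beyond the scatter), this means that two different carbons of the aromatic ring have now taken a further methoxy, each with a modest rise in the number and neither going against that direction, and compound 1 stays the lowest of the series at 63500 nM. Nothing available here accounts for the rise on either carbon.

As far as these compounds go, whether the rise belongs to methoxy itself or would follow any group on this carbon stays open, and a hydroxyl, an amine or a longer chain such as ethoxy in the same place would help to separate the two readings. Also open is what happens to the number when one of the two methoxy groups of compound 1 is replaced by hydrogen, since every step shown here adds a methoxy and none removes one.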